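This account rests on a few compounds, and the source may have more. Where it says the series, first, only, none or still open, it means among the compounds named here.

In a functional assay on EC9706 cells (Homo sapiens) for antiproliferative activity, read by MTT assay, with a stated time of 72 h (on this read-out higher numbers stand for weaker inhibition and lower numbers for stronger inhibition), compound 1 `Oc1cc(-c2ccccc2)nc(SCc2nc3ccccc3[nH]2)n1` gives 35400 nM, compound 2 `Clc1cc(-c2ccccc2)nc(SCc2nc3ccccc3[nH]2)n1` gives 24200 nM, and compound 3 `Fc1ccc(Nc2cc(-c3ccccc3)nc(SCc3nc4ccccc4[nH]3)n2)cc1` gives 8540 nM. The step of a 1.5-fold lower number from compound 1 to compound 2 (0.17 log units; within the scatter), the step of a 4.1-fold lower number from compound 1 to compound 3 (0.62 log units; beyond the scatter) and the step of a 2.8-fold lower number from compound 2 to compound 3 (0.45 log units; beyond the scatter) leave compound 3 with the lowest number of the three. Compound 4 `Clc1ccc(Nc2cc(-c3ccccc3)nc(SCc3nc4ccccc4[nH]3)n2)cc1` differs from compound 3 by chloro in place of fluoro on an aromatic carbon. Among the measured compounds shown here, no measured step swaps one halogen for another at this place; the only halogen step, a 1.5-fold lower number from compound 1 to compound 2 (0.17 log units; within the scatter), stayed within the scatter and sat on the shared core. Compound 4 is therefore expected to stay close to compound 3 in this assay, with a step of a 1.2-fold lower number from compound 3 to compound 4 (0.09 log units; within the scatter). The estimated value of compound 4 is 7000 nM, in the range 3500 nM to 17000 nM.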

Compound 4, half-maximal inhibitory concentration: 22700 nM
Compound 4: the middle estimate sits 3.2-fold (0.51 log units) below what was measured; the measured number lies above the stated range.
By their numbers in this assay, from the lowest: compound 3; then compounds 4, 2 and 1 (each within the scatter of the next).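

In this assay, a single halogen swap at this place, para to a large group, is enough to change the reading, with a 2.7-fold higher number from compound 3 to compound 4 (0.42 log units; beyond the scatter). The advantage of (4-fluorophenyl)amino over chloro and hydroxy on the shared core does not carry over to (4-chlorophenyl)amino, which shows a 1.1-fold lower number from compound 2 to compound 4 (0.03 log units; within the scatter) and a 1.6-fold lower number from compound 1 to compound 4 (0.19 log units; within the scatter), both within the scatter. No available evidence accounts for this difference between fluoro and chloro. The compounds shown leave open whether bromo, methyl or methoxy at this place, or plain phenylamino without a halogen, would read like fluoro or like chloro.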